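Series notes: 4-nitrophenyl for 2-chlorophenyl, cytotoxicity

A few compounds are considered here, and "the series" means these few. Any claim that something is new, unique, unknown or untested is made for them only; others in the source may bear on it.

compound 1 `Cc1ccccc1-c1nn(-c2ccccc2Cl)cc1CNCCN1CCN(C)CC1`: > 20000 nM
compound 2 `Cc1ccccc1-c1nn(-c2ccc(F)cc2F)cc1CN1CCC(N2CCCCC2)CC1`: > 20000 nM

Both measured compounds share a core and differ in the group on the aromatic nitrogen and in the amine side chain. In an ADME assay on Huh-7 cells (Homo sapiens) for cytotoxicity (on this read-out higher numbers stand for lower toxicity in this test and lower numbers for higher toxicity in this test), compound 1 gives > 20000 nM, which is a limit of the assay and not a number. In this assay compound 2 also gives > 20000 nM, again a limit rather than a number. Going by the values given here, compound 1 therefore stands at the edge of what the assay reports, and so does the only other value shown: the limit of > 20000 nM in this assay, at which 2 of the 2 values shown sit. Among the compounds with values here, no pair of measured compounds differs in a single place, so no measured step is available.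

Compound 3 `Cc1ccccc1-c1nn(-c2ccc([N+](=O)[O-])cc2)cc1CNCCN1CCN(C)CC1` is the next compound to be measured. It differs from compound 1 in one place: 4-nitrophenyl in place of 2-chlorophenyl on an aromatic nitrogen. Within the data shown here, both compounds shown sit at the same limit, so the series so far shows no measurable toxicity in this assay up to the top of its range. The step that the limit leaves unreadable from compound 1 to compound 3 is expected to be none beyond the scatter, with the result most likely once more a limit. Compound 3 is thus estimated at 25000 nM in this assay, in the range 8000 nM to 60000 nM.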

Compound 3, half-maximal cytotoxic concentration: > 20000 nM
Compound 3: a limit, no number; the forecaster's own chance of this, stated with the estimate: 75%; the middle value lies beyond the limit too.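

Compound 1 and compound 3 both give a limit and not a number in this assay, so the step between them cannot be read: the limit of > 20000 nM in this assay, at which 3 of the 3 values shown sit.

The compounds shown leave open at what concentration any of them becomes toxic to these cells, and whether 4-nitrophenyl in place of 2-chlorophenyl shifts that concentration at all.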